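Swapping a phenyl for a pyridine ring on a sulfonylurea

This account rests on a few compounds, and the source may have more. Where it says the series, first, only, none or still open, it means among the compounds named here.

The measured compounds and their values:
compound 1, `COc1ccc(Cl)cc1C(=O)NCCC1CCN(S(=O)(=O)NC(=O)NC[C@@H]2C[C@@H]3C=C[C@@H]2C3)CC1`: 27%
compound 2, `CCCNC(=O)NS(=O)(=O)N1CCC(CCNC(=O)c2cc(Cl)ccc2OC)CC1`: 24%
compound 3, `COc1ncccc1C(=O)NCCC1CCN(S(=O)(=O)NC(=O)NC2CCCCC2)CC1`: 22%

All three were tested in a functional assay on the whole organism (blood) with Rattus norvegicus as the target, with stated times of 24 h and 1 h, at a dose of 1 mg/kg by the intraperitoneal route; a higher number here means a stronger effect of the compound at the dose given, a lower number a weaker effect. Compound 1 gives the highest of the three numbers, but its lead is small: compound 2 sits a number 3 percentage points lower from compound 1 to compound 2 (within the scatter), and compound 3 is lower by an amount that also falls within the scatter, so none of the three can be called stronger than another.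

Compound 4, `COc1ncc(Cl)cc1C(=O)NCCC1CCN(S(=O)(=O)NC(=O)NC[C@@H]2C[C@@H]3C=C[C@@H]2C3)CC1`, shares the core of compound 1 and differs only at the ring attached to the carbonyl: 5-chloro-2-methoxypyridin-3-yl in place of 5-chloro-2-methoxyphenyl on a carbonyl carbon.

Among the measured compounds shown here, no measured pair isolates exactly this swap. For the measured compounds named here, the one step at hand, from compound 1 to compound 2, changes a different part of the molecule and stays within the scatter. Compound 3 already carries a methoxypyridine ring in this position, though with a different group on the urea nitrogen and without the chlorine, and its value is within the scatter of that of compound 1. On this evidence the expected change in this assay is none beyond the scatter, and the step from compound 1 to compound 4 is estimated as a number 2 percentage points lower from compound 1 to compound 4 (within the scatter).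

Compound 4 is therefore expected to give about 25%, with a range from 10% to 40%.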

Compound 4, a percentage reported as activity, at one dose (the size of the read-out at that dose, not a potency): 20%
Estimate against measurement, compound 4: 5 percentage points above, within the range that was stated.
By their numbers in this assay, from the lowest: compounds 4, 3, 2 and 1 (each within the scatter of the next).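

This is the one pair shown in which only the ring on the carbonyl carbon changes, with the rest of the molecule held the same. Placing 5-chloro-2-methoxypyridin-3-yl where 5-chloro-2-methoxyphenyl stood gives, in this assay, a number 7 percentage points lower from compound 1 to compound 4 (within the scatter), which means that exchanging a ring carbon for a ring nitrogen here produces no change that can be told apart from the scatter of repeated measurements. Nothing shown connects this result to any property of the two rings, and no explanation of it can be offered.

The compounds shown leave open how a pyrimidine ring or a thiophene ring would behave in this place, and whether a fluorine in place of the chlorine or an ethoxy group in place of the methoxy group would move the number. Among the compounds shown here, the swap is also seen only with the group that compound 1 carries on its urea nitrogen, so its outcome with the propyl group of compound 2 or the cyclohexyl group of compound 3 remains an open question.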